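A few compounds are considered here, and "the series" means these few. Any claim that something is new, unique, unknown or untested is made for them only; others in the source may bear on it.

Series notes. Compound 1 `CCOC(=O)c1nn(-c2ccccc2)c(-c2ccc(OC)cc2OC)c1-c1ccccc1`, compound 2 `CCOC(=O)c1nn(-c2ccccc2)c(-c2ccc(OC)cc2OC)c1C` and compound 3 `COc1ccc(-c2c(C)c(C(=O)O)nn2-c2ccc(Cl)cc2)c(OC)c1` have been run in a functional assay on the whole organism (strain albino) for inhibition, with Rattus norvegicus as the target, read by paw edema, with stated times of 30 min and 2 h, at a dose of 25 mg/kg by the intraperitoneal route; on this read-out higher numbers stand for more inhibition at the one dose given (going by the name of the read-out) and lower numbers for less inhibition; compound 4 `COc1ccc(-c2c(-c3ccccc3)c(C(=O)O)nn2-c2ccc(Cl)cc2)c(OC)c1` has not. In this assay compound 1 gives 20.5%, compound 2 gives 4.86% and compound 3 gives 28.4%; the numbers for compound 1 and compound 3 lie within the scatter of each other. Among the compounds with values here, the one counted step so far, (phenyl in place of methyl on an aromatic carbon), moves the read-out by a number 15.6 percentage points higher from compound 2 to compound 1 (beyond the scatter). Compound 4 carries the same kind of change against compound 3, (phenyl in place of methyl on an aromatic carbon), but around the place the ring atom next to it bears a carboxy group rather than an ethoxycarbonyl group, and the ring atom two ring bonds from it bears a 4-chlorophenyl group rather than a phenyl group. How the core of compound 3 differs from that of compound 2 is not broken down here. The expected step is a number 12.6 percentage points higher from compound 3 to compound 4 (beyond the scatter), set beside the earlier one and resting on a number 15.6 percentage points higher from compound 2 to compound 1 (beyond the scatter). In this assay compound 4 is estimated at 41%, between 26% and 58%.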

Compound 4, a percentage reported as inhibition, in the whole organism at one dose (the size of the read-out at that dose, not a potency): 42%
Compound 4: the middle estimate sits 1 percentage points below what was measured; low and high end bracket the measured number.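

In this assay, phenyl in place of methyl on an aromatic carbon gives a number 13.6 percentage points higher from compound 3 to compound 4 (beyond the scatter) and so repeats on a second core at a matching size: the same change on two cores in this assay, a number 15.6 percentage points higher (beyond the scatter) from compound 2 to compound 1 and a number 13.6 percentage points higher (beyond the scatter) from compound 3 to compound 4, 2 percentage points apart, within the scatter of two such steps.
Within these two pairs, the change therefore carries over despite a carboxy group replacing the ethoxycarbonyl group and a 4-chlorophenyl group replacing the phenyl group. Two cores do not show that it holds on others, and the read-out at a single dose gives no potency.

Left open is how a longer chain or an amine would compare with methyl and phenyl at that aromatic carbon. Also open, going by these compounds, is whether the step would persist with an amide in place of the carboxy group.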